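Chloro in place of bromo: cytotoxicity working notes

The source may hold more compounds than are shown below. What is called first, only, known or untested is meant among the compounds shown, and "the series" means these compounds.

Measured so far:
Compound 1 `N/C(=N/NC(CC(=O)c1ccc(-n2ccnc2)cc1)c1cccc(Br)c1)c1ccccn1` — 51300 nM in an ADME assay on Vero cells (Chlorocebus sabaeus) for cytotoxicity, read by MTT assay, with a stated time of 72 h; a higher number here means that more compound is tolerated, a lower number that less compound is tolerated
Compound 2 `N/C(=N/NC(CC(=O)c1ccc(-n2ccnc2)cc1)c1ccc(Cl)cc1)c1ccccn1` — 78800 nM in this assay

Compound 1 has a single measured neighbour, compound 2, and the two values sit within the scatter of each other: a 1.5-fold higher number from compound 1 to compound 2 (0.19 log units; within the scatter). Nothing in the present numbers separates them.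

The next compound, compound 3 `N/C(=N/NC(CC(=O)c1ccc(-n2ccnc2)cc1)c1cccc(Cl)c1)c1ccccn1`, is compound 1 with one change: chloro in place of bromo on an aromatic carbon. It has not yet been measured in this assay.

Among the measured compounds shown here, only one measured step bears on this move, the one from compound 1 to compound 2, and it changes two things at once, the halogen and its position on the ring, yet stays within the scatter. The change to compound 3 is smaller, keeping the position and swapping only the halogen atom. For the measured compounds named here, no other pair in the set isolates this swap, so no direction can be read from the data; the expectation is a step that does not exceed the scatter, a 1.2-fold higher number from compound 1 to compound 3 (0.07 log units; within the scatter).

For compound 3 the estimated value in this assay is 60000 nM, with a range of 30000 nM to 120000 nM.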

Compound 3, half-maximal cytotoxic concentration: 68600 nM
Beside the measured number, compound 3's estimate is 1.1-fold (0.06 log units) below it, and the stated range covers the measured number.
By their numbers in this assay, from the lowest: compounds 1, 3 and 2 (each within the scatter of the next).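

With the place on the aromatic carbon held fixed, the halogen alone is now isolated: in this assay, the exchange gives a 1.3-fold higher number from compound 1 to compound 3 (0.13 log units; within the scatter) and so does not separate 3-bromophenyl from 3-chlorophenyl. The earlier step changed the halogen and its place together, whereas chloro can now be followed on its own, and moving from 4-chlorophenyl to 3-chlorophenyl gives a 1.1-fold lower number from compound 2 to compound 3 (0.06 log units; within the scatter), again without a separation in this assay. Both single changes therefore stay inside the scatter, so within these three compounds neither the identity of this halogen nor the choice between these two chlorophenyl groups registers as a difference in tolerated compound, and no measurement offers an explanation for these steps.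

All three compounds shown carry a halogen on this ring, so it remains open whether a group of a different kind there, such as an amine, a carboxylic acid or a methoxy group, would also stay inside the scatter. The compounds also leave open how 4-bromophenyl would read and whether changes elsewhere on the shared core would move the number further.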